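The source may hold more compounds than are shown below. What is called first, only, known or untested is meant among the compounds shown, and "the series" means these compounds.

Of the compounds shown here, three built on a shared core have been tested in a functional assay (muscle tissue) with Cavia porcellus as the target; a higher number here means that more compound is needed for the effect, a lower number that less compound is needed. Compound 1 `COC(=O)C1=C(C)N=C(C)/C(=C(\O)OC)C1c1cccc(N(C)C)c1` gives 891 nM, compound 3 `COC(=O)C1=C(C)N=C(C)/C(=C(\O)OC)C1c1cc([N+](=O)[O-])ccc1O` gives 100 nM, and compound 2 `COC(=O)C1=C(C)N=C(C)/C(=C(\O)OC)C1c1ccccc1C(F)(F)F` gives 1.51 nM, the lowest of the three numbers, with its distance to each of the other two lying beyond the usual scatter. Compound 4 `COC(=O)C1=C(C)N=C(C)/C(=C(\O)OC)C1c1ccccc1C` has not yet been measured in this assay. It differs from compound 2 in one place: methyl in place of trifluoromethyl on an aromatic carbon. Among the measured compounds shown here, no measured pair shows this same change, so the size of the step is not known from these data. The exchange of trifluoromethyl for methyl is expected to raise the number, with an estimated step of a 9.9-fold higher number from compound 2 to compound 4 (1.00 log units; beyond the scatter). Compound 4 is therefore expected to give about 15 nM in this assay, within a range from 3 nM to 80 nM.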

Compound 4, half-maximal effective concentration: 6.03 nM
Beside the measured number, compound 4's estimate is 2.5-fold (0.40 log units) above it, within the range that was stated.
By their numbers in this assay, from the lowest: compound 2; then compound 4; then compound 3; then compound 1.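

At this place, on an aromatic carbon ortho to a large group, methyl in place of trifluoromethyl gives a 4.0-fold higher number from compound 2 to compound 4 (0.60 log units; beyond the scatter) and is a modest step. Among the compounds shown here, this is the first step that can be read for a single change, since the earlier compounds differ in more than one place. Nothing shown here explains the step.

As far as these compounds go, whether an amine, a methoxy group or a chlorine at this place would give a number close to those of compound 2 and compound 4 remains open. Also open, from the compounds shown here alone, is whether the same exchange would give a step of similar size elsewhere on the ring.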